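The compounds below may be only part of what the source reports. "The series", "measured", "known", "first", "only" and "open" are said of these compounds alone.

Within the data shown here, in a functional assay on HeLa cells (Homo sapiens) for antiproliferative activity, read by sulforhodamine B assay, with a stated time of 48 h (on this read-out lower numbers stand for stronger inhibition and higher numbers for weaker inhibition), compound 1 `COc1ccc(C[C@@H](O)/C=C/C=C/C(=O)N2CCN(c3ccccc3)CC2)cc1OC` gives 9750 nM, and compound 2 `COc1ccc(C[C@@H](O)/C=C/C=C/C(=O)N2CCN(c3ccccn3)CC2)cc1OC` gives 23600 nM, the higher of the two numbers so far. Compound 3 `COc1ccc(C[C@@H](O)/C=C/C=C/C(=O)N2CCN(c3ncccn3)CC2)cc1OC` changes the same place: pyrimidin-2-yl in place of pyridin-2-yl on an amine nitrogen in a ring. Among the measured compounds shown here, the only measured guide is a 2.4-fold higher number from compound 1 to compound 2 (0.38 log units; beyond the scatter), a modest step beyond the scatter for pyridin-2-yl in place of phenyl. A further modest step in the same direction, towards weaker inhibition, is therefore expected, though one step is thin support. The expected step is a 1.5-fold higher number from compound 2 to compound 3 (0.17 log units; within the scatter). The estimated value for compound 3 is 35000 nM, with an expected range of 14000 nM to 85000 nM.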

Compound 3, half-maximal inhibitory concentration: 12600 nM
Compound 3: the middle estimate sits 2.8-fold (0.44 log units) above what was measured, and the stated range ends above it.
By their numbers in this assay, from the lowest: compounds 1, 3 and 2 (each within the scatter of the next, the first and the last beyond it).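

In this assay, the group on the amine nitrogen in a ring shows no steady trend with the count of ring nitrogens, with a 1.9-fold lower number from compound 2 to compound 3 (0.27 log units; within the scatter) and a 1.3-fold higher number from compound 1 to compound 3 (0.11 log units; within the scatter). Among these compounds, both steps lie within the scatter, so pyrimidin-2-yl cannot be told apart from pyridin-2-yl or phenyl, and only the step from compound 1 to compound 2 lies beyond it. Nothing available bears on why these numbers fall as they do.

Still open, on these data alone, is how a benzyl or acetyl group would read on this nitrogen. Also open, as far as these compounds go, is whether a chlorine or methoxy group on the phenyl ring would shift the number.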